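A few compounds are considered here, and "the series" means these few. Any claim that something is new, unique, unknown or untested is made for them only; others in the source may bear on it.

Measured compounds:
compound 1 `CNC(=O)c1cc(Oc2ccc(/C=C/C(=O)c3ccc([N+](=O)[O-])cc3)cc2)ccn1` — 54300 nM
compound 2 `CNC(=O)c1cc(Oc2ccc(/C=C/C(=O)c3ccc(C)cc3)cc2)ccn1` — 24900 nM
compound 3 `CNC(=O)c1cc(Oc2ccc(C(=O)/C=C/c3ccc(Cl)cc3Cl)cc2)ccn1` — 3990 nM

In a functional assay on MCF7 cells (Homo sapiens) for cytotoxicity, read by MTT assay, with a stated time of 72 h (on this read-out higher numbers stand for weaker inhibition and lower numbers for stronger inhibition), compound 3 gives the lowest number of the three; compound 2 sits above it, and compound 1 sits highest of all. Compound 4 `CNC(=O)c1cc(Oc2ccc(C(=O)/C=C/c3ccc(Br)cc3)cc2)ccn1` has not yet been measured in this assay. It differs from compound 3 in one place: 4-bromophenyl in place of 2,4-dichlorophenyl on a double-bonded chain carbon bound to a double-bonded chain carbon.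

Going by the values given here, the only measured single-place step, a 2.2-fold lower number from compound 1 to compound 2 (0.34 log units; beyond the scatter), concerns the aromatic carbon at the other end of the shared core and not the group on the double-bonded chain carbon that is exchanged here, so it bears on compound 4 only as an indication that changing a substituent on an outer aromatic group shifts the number by a modest amount. Among the compounds with values here, no measured pair exchanges 2,4-dichlorophenyl for 4-bromophenyl, and no pair varies that position at all, so direction is open. Compound 4 is therefore expected to land near compound 3, most likely a little higher, with the step of a 2.0-fold higher number from compound 3 to compound 4 (0.30 log units; within the scatter) estimated as modest. The estimate for compound 4 in this assay is 8000 nM, within 2500 nM to 25000 nM.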

Compound 4, half-maximal inhibitory concentration: > 50000 nM
Compound 4 was reported as a limit; the forecaster's own chance of this, stated with the estimate: 5%; middle value at least 6.2-fold (0.79 log units) away from the limit.
By their numbers in this assay, from the lowest: compound 3; then compound 2; then compound 1.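

In this assay, the aryl group on a double-bonded chain carbon bound to a double-bonded chain carbon proves to be a sensitive place in this series: 4-bromophenyl in place of 2,4-dichlorophenyl gives an at least 12-fold higher number from compound 3 to compound 4 (1.09 log units; beyond the scatter). The earlier step, a 2.2-fold lower number from compound 1 to compound 2 (0.34 log units; beyond the scatter), concerned a different place and gave no sign of a change this large at the group exchanged here. Compound 4 stands as a limit and not as a number: the limit of > 50000 nM in this assay, at which 1 of the 4 values shown sits.

The exchange alters the halogen and the substitution pattern together, so the compounds shown leave open which of the two matters, and a 4-chlorophenyl or 2-chlorophenyl group at this place would separate them. Also open, from the compounds shown here alone, is how this place responds to a group without halogen, such as an aminophenyl group.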